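Bromo in place of propyl on the shared core

The source may report more compounds than this note shows. Statements on the series, on what has been measured and on what is new or still open speak of the compounds shown alone.

Compound 1 `C=CCc1ccccc1OCC1=NCCN1`, in an assay on isolated protein for binding affinity to Alpha-2B adrenergic receptor (Homo sapiens) (a higher number here means a weaker inhibitor, a lower number a stronger inhibitor), compound 1 gives 708 nM.
Compound 2 `c1ccc(OCC2=NCCN2)c(CC2CC2)c1`, in this assay compound 2 gives 501 nM.
Compound 3 `CCCc1ccccc1OCC1=NCCN1`, in this assay compound 3 gives 550 nM.

Compound 3 stands second highest of the three numbers; its nearest neighbour is compound 2, its furthest compound 1, and both gaps lie within the scatter. The three compounds differ only in the group on a saturated chain carbon bound to an aromatic carbon, and none of the steps among them reaches beyond the scatter: a 1.4-fold lower number from compound 1 to compound 2 (0.15 log units; within the scatter), a 1.3-fold lower number from compound 1 to compound 3 (0.11 log units; within the scatter), and a 1.1-fold higher number from compound 2 to compound 3 (0.04 log units; within the scatter).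

Compound 4 `Brc1ccccc1OCC1=NCCN1` departs from compound 3 in a different way: bromo in place of propyl on an aromatic carbon. Among the measured compounds shown here, no measured step exchanges a chain for a halogen, so the three steps bear on it only indirectly. What they show is that the shared core with an oxygen-linked imidazoline held its numbers in a narrow band while the chain was varied. On that ground, the step from compound 3 to compound 4 in this assay is expected to be small, a 1.2-fold lower number from compound 3 to compound 4 (0.09 log units; within the scatter), though with a wider range than the chain exchanges. For compound 4 the expected value in this assay is 450 nM, between 150 nM and 1400 nM.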

Compound 4, inhibition constant: 617 nM
Beside the measured number, compound 4's estimate is 1.4-fold (0.14 log units) below it; the range from low to high includes it.
By their numbers in this assay, from the lowest: compounds 2, 3, 4 and 1 (each within the scatter of the next).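

In this assay, among the compounds shown here, the earlier compounds varied only a chain, whereas this exchange puts a single bromine atom on the aromatic carbon in place of the 3-carbon propyl, and the result is a 1.1-fold higher number from compound 3 to compound 4 (0.05 log units; within the scatter). The comparisons with the other two chains read the same way, with a 1.2-fold higher number from compound 2 to compound 4 (0.09 log units; within the scatter) for bromo in place of cyclopropylmethyl and a 1.1-fold lower number from compound 1 to compound 4 (0.06 log units; within the scatter) for bromo in place of allyl, so at this position, among these four compounds, the number does not separate a halogen from a carbon chain, nor a one-atom group from the larger chains. Nothing available here accounts for this lack of separation.

The compounds shown leave open whether any group at this aromatic carbon would carry the number beyond the scatter, since all four substituents lack hydrogen-bond donors and acceptors and none is charged; an amine, a hydroxyl, a carboxylic acid or a much longer chain might behave differently. They also leave open whether fluoro or chloro would match bromo here, and whether bromo would give a similar number at another carbon of the aromatic ring.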